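Cytotoxicity limits across three side-chain variants

A few compounds are considered here, and "the series" means these few. Any claim that something is new, unique, unknown or untested is made for them only; others in the source may bear on it.

Measured so far:
compound 1 `O=C1CSC(=O)N1C[C@H]1CN(c2ccc(-n3cc(-c4ccccn4)cn3)c(F)c2)C(=O)O1` — in an ADME assay on L02 cells (Homo sapiens) for cytotoxicity, read by MTT assay, with a stated time of 48 h (a higher number here means a weaker inhibitor, a lower number a stronger inhibitor), compound 1 gives only the limit > 400 ug/mL
compound 2 `O=C1O[C@@H](CSc2cccs2)CN1c1ccc(-n2cc(-c3ccccn3)cn2)c(F)c1` — in this assay compound 2 gives only the limit > 400 ug/mL
compound 3 `CCNC(=O)NC[C@H]1CN(c2ccc(-n3cc(-c4ccccn4)cn3)c(F)c2)C(=O)O1` — in this assay compound 3 gives only the limit > 400 ug/mL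

Compound 1 stands at the assay limit, as do both other measured compounds (the limit of > 400 ug/mL in this assay, at which 3 of the 3 values shown sit). The step to compound 4 `O=C1O[C@@H](CNC(=O)C(F)(F)F)CN1c1ccc(-n2cc(-c3ccccn3)cn2)c(F)c1` is ((trifluoromethyl)carbonyl)amino in place of 2,4-dioxo-1,3-thiazolidin-3-yl on a saturated chain carbon bound to a saturated ring carbon. The measured steps at the same place, a step that the two limits leave unreadable from compound 1 to compound 2 and a step that the two limits leave unreadable from compound 1 to compound 3, are both unreadable, so no readable change at this position is known. Compound 4 is therefore expected to sit at the limit as well, with a step that the limit leaves unreadable from compound 1 to compound 4 that means no movement beyond the scatter. The estimate for compound 4 is 450 ug/mL, between 250 ug/mL and 800 ug/mL.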

Compound 4, half-maximal inhibitory concentration: > 400 ug/mL
Compound 4: no number, only a limit; the forecaster's own chance of this, stated with the estimate: 85%; the middle value is on the limit's open side.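

Compound 4 gives only a limit, like compound 1, compound 2 and compound 3, so its steps to all three cannot be read: the limit of > 400 ug/mL in this assay, at which 4 of the 4 values shown sit.

The compounds shown leave open whether any of these side chains differs from another in this assay.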